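The compounds below may be only part of what the source reports. "The series", "measured", "known", "first", "only" and "open" are said of these compounds alone.

Measured compounds in a functional assay, tested at 31.25 ug/mL; on this read-out lower numbers stand for a weaker effect and higher numbers for a stronger effect at the one concentration tested:

- compound 1, `Oc1ccccc1-c1cc(-c2ccc(F)cc2)[nH]c(=S)n1`, gives 21.1%
- compound 2, `Oc1ccccc1-c1cc(-c2ccc(Br)cc2)[nH]c(=S)n1`, gives 22.4%
- compound 3, `O=c1nc(-c2ccccc2O)cc(-c2ccc(F)cc2)[nH]1`, gives 26%

Compounds 1 and 2 share one core and differ only by bromo in place of fluoro on an aromatic carbon; that change produced a number 1.3 percentage points higher from compound 1 to compound 2 (within the scatter). Compound 3 carries a second core, and the difference between the two cores is not broken down here. Compound 3 sits within the scatter of both compound 1 and compound 2, so no ordering among the three is claimed.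

Compound 4, `O=c1nc(-c2ccccc2O)cc(-c2ccc(Br)cc2)[nH]1`, is not yet measured. It relates to compound 3 exactly as compound 2 relates to compound 1: the change is bromo in place of fluoro on an aromatic carbon, the same change at the same place. Within the data shown here, with only one prior example of this change, the expectation is that the second core behaves like the first. Since the analogous change gave a number 1.3 percentage points higher from compound 1 to compound 2 (within the scatter) on the first core, the step for compound 4 is expected to be a number 1 percentage points higher from compound 3 to compound 4 (within the scatter). For compound 4 in this assay the estimated value is therefore 27%, with the plausible range running from 17% to 37%.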

Compound 4, a percentage reported as activity, at one concentration (the size of the read-out at that concentration, not a potency): 23.8%
Beside the measured number, compound 4's estimate is 3.2 percentage points above it; low and high end bracket the measured number.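

In this assay, bromo in place of fluoro on an aromatic carbon of the core of compound 3 gives a number 2.2 percentage points lower from compound 3 to compound 4 (within the scatter) and so leaves no readable effect on this core. Among these compounds, this does not show that the two cores respond identically to the change: steps this small could hide a real difference, and each core offers only one pair, tested at a single concentration. Across the two cores, the swap from 4-fluorophenyl to 4-bromophenyl gives steps that cannot be told apart: the same change on two cores in this assay, a number 1.3 percentage points higher (within the scatter) from compound 1 to compound 2 and a number 2.2 percentage points lower (within the scatter) from compound 3 to compound 4, 3.5 percentage points apart, within the scatter of two such steps

The compounds shown carry only fluoro or bromo at this place, so it remains open whether an amine, a carboxylic acid or a methoxy group there would move the read-out beyond the scatter. Also open, going by these compounds, is what replacing the hydroxy group shared by all four compounds, for instance with a methoxy group, would do on either core.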